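From Compound 3 to Compound 4: Reading Past a Limit

The source may hold more compounds than are shown below. What is called first, only, known or untested is meant among the compounds shown, and "the series" means these compounds.

Compound 3 (`CS(=O)(=O)Nc1ccc2c(c1)S(=O)(=O)N=C(c1c(O)c(-c3cccs3)nn(CC3(C(F)(F)F)CC3)c1=O)N2`) carries a 1-(trifluoromethyl)cyclopropyl group on the shared core. In an ADME assay on Huh-7 cells (Homo sapiens) for cytotoxicity, with a stated time of 72 h (on this read-out lower numbers stand for higher toxicity in this test and higher numbers for lower toxicity in this test), compound 3 gives > 1000 nM, which is a limit and not a number. Compound 1 (`CCC(C)(C)Cn1nc(-c2cccs2)c(O)c(C2=NS(=O)(=O)c3cc(NS(C)(=O)=O)ccc3N2)c1=O`) gives > 1000 nM, which is also a limit. Compound 2 (`CS(=O)(=O)Nc1ccc2c(c1)S(=O)(=O)N=C(c1c(O)c(-c3cccs3)nn(CCC3CC3)c1=O)N2`) gives > 33000 nM, likewise a limit. Compound 3 therefore has no exact place among these three compounds.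

Compound 4 (`CS(=O)(=O)Nc1ccc2c(c1)S(=O)(=O)N=C(c1c(O)c(-c3cccs3)nn(CCC3CCC3)c1=O)N2`) has not yet been measured. It differs from compound 3 by cyclobutylmethyl in place of 1-(trifluoromethyl)cyclopropyl on a saturated chain carbon bound to an aromatic nitrogen, with cyclobutylmethyl in place of 1-(trifluoromethyl)cyclopropyl on a saturated chain carbon bound to an aromatic nitrogen.

Three measured comparisons bear on this change, and none has a readable size: a step that the two limits leave unreadable from compound 2 to compound 3, a step that the two limits leave unreadable from compound 1 to compound 2 and a step that the two limits leave unreadable from compound 1 to compound 3. The closest is a step that the two limits leave unreadable from compound 2 to compound 3, which links 1-(trifluoromethyl)cyclopropyl with cyclopropylmethyl, another group with a ring of carbon only.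

The expectation leans on compound 2, whose limit is > 33000 nM. In this assay a move towards higher numbers is thus expected, although its size remains uncertain. The expected change is a step that the limit leaves unreadable from compound 3 to compound 4. Compound 4 is estimated at 20000 nM, with an expected range of 3000 nM to 50000 nM.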

Compound 4, half-maximal cytotoxic concentration: > 1000 nM
Compound 4: a limit, no number (the forecaster's own chance of this, stated with the estimate: 85%); the middle value is on the limit's open side.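

In this assay compound 4 gives > 1000 nM as a limit and not a number. The steps to it from compound 1, compound 2 and compound 3 each join two limits, and none can be read. The compounds shown leave open whether these four groups differ in this read-out at all, and by how much.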